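Hydroxyalkyl amino variants on a shared core

The source may report more compounds than this note shows. Statements on the series, on what has been measured and on what is new or still open speak of the compounds shown alone.

Compound 2 `CC(O)CNc1nc(-c2ccccc2)nc2c1nnn2Cc1ccccc1F` gives 4800000 nM in an assay on isolated protein for binding affinity to adenosine receptor A1 (Bos taurus) (on this read-out higher numbers stand for weaker inhibition and lower numbers for stronger inhibition), the higher of the two numbers in hand. Among the measured compounds shown here, compound 1 `OC1CCC(Nc2nc(-c3ccccc3)nc3c2nnn3Cc2ccccc2F)CC1` gives 1850000 nM, and the step of a 2.6-fold higher number from compound 1 to compound 2 (0.41 log units; beyond the scatter) is the only measured change in the set. Compound 3 `OCCNc1nc(-c2ccccc2)nc2c1nnn2Cc1ccccc1F` carries hydrogen in place of methyl on a saturated chain carbon bound to an oxygen on a saturated carbon and a saturated chain carbon. For the measured compounds named here, no measured step tracks a change of this kind; the one step in hand concerns a different replacement and gives no direct guide. The expectation for a 1.1-fold lower number from compound 2 to compound 3 (0.03 log units; within the scatter) is therefore a step of no size beyond the scatter, in no set direction. Compound 3 is estimated at 4500000 nM, within 1500000 nM to 13000000 nM.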

Compound 3, inhibition constant: 54000000 nM
Estimate against measurement, compound 3: 12-fold (1.08 log units) below, and the stated range ends below it.
By their numbers in this assay, from the lowest: compound 1; then compound 2; then compound 3.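

In this assay, this single methyl matters: hydrogen in its place on the saturated chain carbon, giving 2-hydroxyethyl from 2-hydroxypropyl, produces a large step (an 11-fold higher number from compound 2 to compound 3 (1.05 log units; beyond the scatter)). Set against 4-hydroxycyclohexyl, the 2-hydroxyethyl group gives an even wider separation (a 29-fold higher number from compound 1 to compound 3 (1.47 log units; beyond the scatter)), so the small chain change is not a neutral one in this series. No measurement in hand accounts for the step. Still open, as far as these compounds go, is how a longer chain such as 3-hydroxypropyl would read on this core. From the compounds shown here alone, an amine in place of the hydroxyl also remains open.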